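From 1-carboxy-2-methylpropyl to 1-carboxyethyl on the amine nitrogen

The source may hold more compounds than are shown below. What is called first, only, known or untested is meant among the compounds shown, and "the series" means these compounds.

- compound 1 `CSCC[C@H](NC1=CC(=O)C=C(C[C@]2(C)[C@@H](C)CC[C@]3(C)C(C)=CCC[C@@H]23)C1=O)C(=O)O` gives > 200000 nM (a limit)
- compound 2 `CC1=CCC[C@H]2[C@](C)(CC3=CC(=O)C=C(N[C@@H](C(=O)O)C(C)C)C3=O)[C@@H](C)CC[C@]12C` gives 85400 nM (a number)

Among the compounds with values here, in an ADME assay on MRC5 cells (Homo sapiens) for cytotoxicity, read by MTT assay, with a stated time of 72 h (a lower number here means a stronger inhibitor, a higher number a weaker inhibitor), compound 2 gives 85400 nM, the only actual number so far. Compound 1 stands at a limit of the assay: the limit of > 200000 nM in this assay, at which 1 of the 2 values shown sits.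

Compound 3 `CC1=CCC[C@H]2[C@](C)(CC3=CC(=O)C=C(N[C@@H](C)C(=O)O)C3=O)[C@@H](C)CC[C@]12C` differs from compound 2 by 1-carboxyethyl in place of 1-carboxy-2-methylpropyl on an amine nitrogen. Within the data shown here, one measured step bears on this, also a swap on an amine nitrogen: an at least 2.3-fold lower number from compound 1 to compound 2 (0.36 log units; beyond the scatter). Its true size is open, as one end is a limit. Among the measured compounds shown here, with only this guide, a modest shift toward a higher number in this assay is expected, possibly none beyond the scatter. The expected step is a 1.4-fold higher number from compound 2 to compound 3 (0.15 log units; within the scatter). For compound 3 the estimate is 120000 nM, with an expected range of 50000 nM to 260000 nM.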

Compound 3, half-maximal inhibitory concentration: 157000 nM
Beside the measured number, compound 3's estimate is 1.3-fold (0.12 log units) below it; the measured number falls inside the stated range.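

In this assay, 1-carboxyethyl in place of 1-carboxy-2-methylpropyl on the amine nitrogen gives a 1.8-fold higher number from compound 2 to compound 3 (0.26 log units; within the scatter), so this swap does not separate the two compounds. As far as these compounds go, the other new step, hydrogen in place of (methylsulfanyl)methyl on a saturated chain carbon, reads an at least 1.2-fold lower number from compound 1 to compound 3 (0.10 log units; that floor lies within the scatter), and its true size stays open. Compound 1 is a limit and not a number, so that step is bounded from one side only: the limit of > 200000 nM in this assay, at which 1 of the 3 values shown sits.

Every compound shown carries a carboxylic acid in the group on the amine nitrogen, so what a methyl ester or a primary amide would do there remains open. Also open, from the compounds shown here alone, is how a longer chain ending in a hydroxyl or an amine would read in this assay.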